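The compounds below may be only part of what the source reports. "The series", "measured", "known", "first", "only" and "open" are said of these compounds alone.

Compound 2 `FC(F)(F)c1ccc(Nc2cc3[nH]c(-c4cccc(C(F)(F)F)c4)nc3cn2)nc1` stands highest of the two compounds measured in an ADME assay on microsomes from liver (Homo sapiens) for metabolic stability, read by LC-MS, with a stated time of 30 min, tested at 0.1 uM; a higher number here means that more of the compound is left, a lower number that less of the compound is left: compound 2 gives 90%, whereas compound 1 `COc1cccc(Nc2cc3[nH]c(-c4cccc(C(F)(F)F)c4)nc3cn2)n1` gives 45%, a step of a number 45 percentage points higher from compound 1 to compound 2 (beyond the scatter). Compound 3 `FC1(F)CC(c2nc3cnc(Nc4ccc(C(F)(F)F)cn4)cc3[nH]2)C1` differs from compound 2 in one place: 3,3-difluorocyclobutyl in place of 3-(trifluoromethyl)phenyl on an aromatic carbon. Among the measured compounds shown here, no measured step alters this part of the shared core, so the single known step, which concerns a different position, does not bear directly on it. A modest downward step is nevertheless expected, a number 15 percentage points lower from compound 2 to compound 3 (beyond the scatter), since compound 2 gives 90% near the top of the scale. Compound 3 is expected to give about 75%, somewhere between 50% and 95%.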

Compound 3, percent of the compound remaining: 88%
Compound 3: middle estimate off by 13 percentage points, on the low side; low and high end bracket the measured number.
By their numbers in this assay, from the lowest: compound 1; then compounds 3 and 2 (each within the scatter of the next).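

In this assay, the aromatic 3-(trifluoromethyl)phenyl gives way to the non-aromatic 3,3-difluorocyclobutyl with a number 2 percentage points lower from compound 2 to compound 3 (within the scatter), so at this position a benzene ring is not needed to keep the number high. Among the compounds shown here, the earlier step changed a different place, the group on the nitrogen, so this is the first reading of this position. Nothing available explains why the two numbers lie so close. Still open, going by these compounds, is whether a ring or chain without fluorine, such as plain cyclobutyl or a longer alkyl chain, or a group carrying an amine, would behave the same way here.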